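This account rests on a few compounds, and the source may have more. Where it says the series, first, only, none or still open, it means among the compounds named here.

Measured in a functional assay on MDA-MB-231 cells (Homo sapiens) for antiproliferative activity, read by MTT assay, with a stated time of 72 h; on this read-out lower numbers stand for stronger inhibition and higher numbers for weaker inhibition:
- compound 1 `COc1cc(OC)cc(-c2cccc(NC(=O)CCc3ccc4c(c3)B(O)OC4)c2)c1`: 21000 nM
- compound 2 `COc1cc(OC)cc(-c2cccc(NC(=O)CCc3ccc4c(c3)COB4O)c2)c1`: 77000 nM

Compound 2 holds the higher of the two numbers. Compound 3 `COc1cc(OC)cc(-c2cccc(NC(=O)CCc3cccc4c3COB4O)c2)c1` has the same atoms as compound 2, joined differently: a group of 10 heavy atoms (7 carbon, 1 boron, 2 oxygen; one five-membered non-aromatic ring with 2 hetero atoms, one six-membered aromatic ring of carbon only) in place of a group of 10 heavy atoms (7 carbon, 1 boron, 2 oxygen; one five-membered non-aromatic ring with 2 hetero atoms, one six-membered aromatic ring of carbon only), on a saturated chain carbon, two bonds along the chain from a carbonyl carbon.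

Going by the values given here, one measured step bears on this change: a 3.7-fold higher number from compound 1 to compound 2 (0.56 log units; beyond the scatter). That modest step involves the same kind of exchange at the same place, so rearranging this group can move the number in this assay beyond the scatter. It does not show which way the new arrangement will go. With compound 1 at 21000 nM as the only other reference, a number between the two measured values seems the most reasonable expectation.

The expected change is small and towards a lower number: a 1.7-fold lower number from compound 2 to compound 3 (0.23 log units; within the scatter).

The estimate for compound 3 is 45000 nM, with an expected range of 15000 nM to 120000 nM.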

Compound 3, half-maximal inhibitory concentration: 93000 nM
Estimate against measurement, compound 3: 2.1-fold (0.32 log units) below; the measured number falls inside the stated range.
By their numbers in this assay, from the lowest: compound 1; then compounds 2 and 3 (each within the scatter of the next).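

In this assay, a further rearrangement of the group on the saturated chain carbon, two bonds along the chain from a carbonyl carbon, gives a 1.2-fold higher number from compound 2 to compound 3 (0.08 log units; within the scatter), so this second change does not separate compound 2 and compound 3. The comparison with the third arrangement gives a 4.4-fold higher number from compound 1 to compound 3 (0.65 log units; beyond the scatter), so compound 1 now stands apart from both other compounds, and the earlier step is no longer a lone contrast between two arrangements. No measurement shown explains why the arrangement in compound 1 differs from the other two.

Even compound 1 gives only 21000 nM, and all three compounds share the same group atoms and chain. On these data alone, whether an open-chain boronic acid, a carboxylic acid or a longer chain would shift the number at this place remains open.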